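The source may report more compounds than this note shows. Statements on the series, on what has been measured and on what is new or still open speak of the compounds shown alone.

Measured in a functional assay on A549 cells (Homo sapiens) for inhibition, read by CCK-8 assay, with a stated time of 72 h, tested at 8 uM; a lower number here means less inhibition of growth, a higher number more inhibition of growth at the concentration tested:
compound 1 `Nc1ccccc1NC(=O)c1ccc(CSc2cccc(F)c2)cc1`: 72.7%
compound 2 `Cc1ccc(SCc2ccc(C(=O)Nc3ccccc3N)cc2)cc1`: 78.3%
compound 3 `Nc1ccccc1NC(=O)c1ccc(CSc2ccc(F)cc2)cc1`: 44.5%

Compound 3 stands lowest of the three, beyond the scatter from both others. The next change leads to compound 4 `Nc1ccccc1NC(=O)c1ccc(CSc2ccc(Cl)cc2)cc1`: chloro in place of fluoro on an aromatic carbon, para to a large group. The closest measured step is a number 33.8 percentage points lower from compound 2 to compound 3 (beyond the scatter), with fluoro taking the place of methyl on that same carbon. The step of a number 28.2 percentage points lower from compound 1 to compound 3 (beyond the scatter) also bears on it, as a second drop on reaching the 4-fluorophenyl group. For the measured compounds named here, no chloro compound has been measured yet, so the size remains uncertain. A rise beyond the scatter in this assay is expected, though smaller than the step from methyl to fluoro. The expected step is a number 19.5 percentage points higher from compound 3 to compound 4 (beyond the scatter). The estimate for compound 4 is 64%, with an expected range of 46% to 82%.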

Compound 4, percent growth inhibition at one concentration: 50.4%
Compound 4: the middle estimate sits 13.6 percentage points above what was measured, and the stated range covers the measured number.
By their numbers in this assay, from the lowest: compounds 3 and 4 (each within the scatter of the next); then compounds 1 and 2 (each within the scatter of the next).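

In this assay, chloro in place of fluoro on this carbon, para to a large group, gives a number 5.9 percentage points higher from compound 3 to compound 4 (within the scatter) and so does not separate the two halogens here. The low standing is therefore not confined to fluoro: against the methyl group there is a number 27.9 percentage points lower from compound 2 to compound 4 (beyond the scatter) as well. Moving from the 3-fluorophenyl group to the 4-chlorophenyl group likewise gives a number 22.3 percentage points lower from compound 1 to compound 4 (beyond the scatter).

No measured property of these compounds bears on these differences. As far as these compounds go, how a methoxy group or an amine on this carbon would read remains open, as does the 3-chlorophenyl group on the sulfur.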